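The source may hold more compounds than are shown below. What is called first, only, known or untested is meant among the compounds shown, and "the series" means these compounds.

This study concerns three compounds that share one core and differ only in the side chain attached to it. Compound 1 `CCCCc1nc(C(C)C)c(CC(=O)OCC(F)(F)F)c(=O)n1Cc1ccc(-c2ccccc2-c2noc(=O)[nH]2)cc1` has no reported result: in an ADME assay on microsomes from liver (Homo sapiens) for metabolic stability, with a stated time of 30 min (on this read-out higher numbers stand for a more stable compound and lower numbers for a less stable compound), compound 1 gives "not determined" (no result reported). Among the compounds with values here, compound 2 `CCCCc1nc(C(C)C)c(CC(=O)OC2CC2)c(=O)n1Cc1ccc(-c2ccccc2-c2noc(=O)[nH]2)cc1` is the only one with a number: in this assay compound 2 gives 10.3%, which leaves compound 2 as the sole reference point in this set and marks a compound of which little remains after the stated time. Compound 3 `CCCCc1nc(C(C)C)c(C(C)C(=O)OCC)c(=O)n1Cc1ccc(-c2ccccc2-c2noc(=O)[nH]2)cc1` has not yet been measured. It differs from compound 2 in one place: 1-(ethoxycarbonyl)ethyl in place of (cyclopropyloxycarbonyl)methyl on an aromatic carbon. The ring of the old side chain is gone, and the new one is a straight chain with a branch at its first carbon. Within the data shown here, no step between two measured compounds is available, so there is nothing to scale this change against. A step of modest size in this assay is expected, pointing upward, though it may well stay within the scatter of repeated runs. The estimate for compound 3 is 16%, with a range from 5% to 35%. The step this implies is expected to be a number 5.7 percentage points higher from compound 2 to compound 3 (within the scatter).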

Compound 3, percent of the compound remaining: 11%
Compound 3: the middle estimate sits 5 percentage points above what was measured, within the range that was stated.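

In this assay, within the data shown here, putting 1-(ethoxycarbonyl)ethyl in place of (cyclopropyloxycarbonyl)methyl on this aromatic carbon gives a number 0.7 percentage points higher from compound 2 to compound 3 (within the scatter), the first step that can be read at this position. The change removes the three-membered ring and adds a branch at the first carbon of the side chain, while the counts of heavy atoms and hydrogen-bond acceptors stay the same, and the read-out does not separate the two compounds, so this particular rearrangement of the side chain shows no measurable effect on stability here. No measurement shown bears on what lies behind this result, so the data offer no explanation for it.

On these data alone, compound 1, which carries a trifluoroethyl ester at the same position, gives "not determined" (no result reported) in this assay, so any step involving it cannot be read, and the effect of fluorine in this side chain remains unknown. Also open, as far as these compounds go, is whether a side chain of a different kind on this aromatic carbon, such as a carboxylic acid, an amide or a longer chain, would leave more of the compound remaining after the stated time.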